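Fluorophenoxy isomers on the coumarin ether series

The source may hold more compounds than are shown below. What is called first, only, known or untested is meant among the compounds shown, and "the series" means these compounds.

Measured so far:
compound 1 `Cc1ccc(Oc2c(/C=N\CCCCCOc3cc4oc(=O)cc(C)c4cc3Cl)c(C)nn2C)cc1` — 11100 nM
compound 2 `Cc1nn(C)c(Oc2ccccc2F)c1/C=N\CCCCCCOc1cc2oc(=O)cc(C)c2cc1Cl` — > 25000 nM

In a functional assay on SMMC-7721 cells (Homo sapiens) for antiproliferative activity, read by MTT assay, with a stated time of 72 h (on this read-out lower numbers stand for stronger inhibition and higher numbers for weaker inhibition), compound 1 gives 11100 nM. Compound 2 returns only a limit, > 25000 nM, so its actual value is not known; it sits at the limit of > 25000 nM in this assay, at which 1 of the 2 values shown sits. Compound 3 `Cc1nn(C)c(Oc2cccc(F)c2)c1/C=N\CCCCCCOc1cc2oc(=O)cc(C)c2cc1Cl` differs from compound 2 by 3-fluorophenyl in place of 2-fluorophenyl on an oxygen on an aromatic ring. For the measured compounds named here, with compound 2 known only as a limit, no measured step guides this change; the expected step of an at least 1.2-fold lower number from compound 2 to compound 3 (0.09 log units; that floor lies within the scatter) is small, with no direction beyond the scatter. Compound 3 is estimated at 20000 nM, between 8000 nM and 50000 nM.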

Compound 3, half-maximal inhibitory concentration: 23600 nM
The estimate for compound 3 lay 1.2-fold (0.07 log units) below the measured number; the measured number falls inside the stated range.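

In this assay, for the compounds shown here, compound 3 gives 23600 nM, the first actual number for a fluorophenoxy isomer on this chain. Moving from 2-fluorophenyl to 3-fluorophenyl on the oxygen gives an at least 1.0-fold lower number from compound 2 to compound 3 (0.02 log units; that floor lies within the scatter). Compound 2 stands only as a limit of the assay, so the true size of this step stays unknown: the limit of > 25000 nM in this assay, at which 1 of the 3 values shown sits.

From the compounds shown here alone, whether the two isomers truly differ beyond the scatter remains open. Also open, going by these compounds, is how an amine or a carboxylic acid on this phenyl ring, or a longer chain, would read in this assay.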